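A few compounds are considered here, and "the series" means these few. Any claim that something is new, unique, unknown or untested is made for them only; others in the source may bear on it.

Compound 2, `Cc1c(OCCCCOc2ccc(F)c(C(=O)O)c2)ccc(C(=O)CC2CCCC2)c1O`, is one of two compounds in this set with a number in an assay on HEK293 cells for positive allosteric modulation of metabotropic glutamate receptor 3 (Rattus norvegicus), read by thallium flux, with a stated time of 2.5 min; on this read-out higher numbers stand for an effect only at larger amounts of compound and lower numbers for an effect already at smaller amounts. In this assay compound 2 gives 2490 nM. That is the highest of the two numbers. Going by the values given here, the nearest neighbour is compound 3, `CCCC(=O)c1ccc(OCCCCOc2ccc(F)c(C(=O)O)c2)c(C)c1O`, which in this assay gives 438 nM; the single measured step, a 5.7-fold lower number from compound 2 to compound 3 (0.75 log units; beyond the scatter), comes with ethyl in place of cyclopentyl on a saturated chain carbon bound to a carbonyl carbon. Compound 1, `CCC(=O)c1ccc(OCCCCOc2ccc(F)c(C(=O)O)c2)c(C)c1O`, in this assay gives "not determined" (no result reported), so no result is reported for it.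

Compound 4, `Cc1c(OCCCCOc2ccc(C(=O)O)cc2F)ccc(C(=O)CC2CCCC2)c1O`, differs from compound 2 by 4-carboxy-2-fluorophenyl in place of 3-carboxy-4-fluorophenyl on an oxygen on a saturated carbon. Among the compounds with values here, no measured step touches this part of the molecule; the only step known, from compound 2 to compound 3, concerns the carbonyl side and gives no guidance on the aryl ether end. The expectation therefore rests on compound 2 alone, with a wide range. The step from compound 2 to compound 4 is estimated as a 1.2-fold higher number from compound 2 to compound 4 (0.08 log units; within the scatter), with no confident direction. For compound 4 the estimated value is 3000 nM, expected to lie between 700 nM and 13000 nM.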

Compound 4, half-maximal effective concentration: > 10000 nM
Compound 4 ended at the assay's limit; the forecaster's own chance of this, stated with the estimate: 15%; at least 3.3-fold (0.52 log units) between middle value and limit.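

Replacing 3-carboxy-4-fluorophenyl with 4-carboxy-2-fluorophenyl, which uses the same atoms joined differently, gives an at least 4.0-fold higher number from compound 2 to compound 4 (0.60 log units; beyond the scatter). This shows that in this assay the result depends on the arrangement at the aryl ether end, whereas the earlier step concerned only the carbonyl side. Compound 4 gives > 10000 nM, which is a limit of the assay and not a number, so the step has a lower bound only: the limit of > 10000 nM in this assay, at which 1 of the 4 values shown sits.

Going by these compounds, it remains open whether the same exchange would have a comparable effect on compound 3, which carries ethyl in place of cyclopentyl on the saturated chain carbon bound to the carbonyl carbon. Also open, on these data alone, is what a tetrazole in place of the carboxylic acid, a 3-carboxyphenyl group without fluorine, or a longer chain between the two ether oxygens would give.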